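Swapping the Sulfonamide Substituent on a Quinoline Core

The source may hold more compounds than are shown below. What is called first, only, known or untested is meant among the compounds shown, and "the series" means these compounds.

Of the compounds shown here, three built on one shared core have been tested so far in an ADME assay on microsomes from liver (Mus musculus) for metabolic stability, read by LC-MS, using NADPH, with a stated time of 30 min, tested at 0.1 uM; on this read-out higher numbers stand for a more stable compound and lower numbers for a less stable compound. Compound 1, `O=S(=O)(NCC1COC1)c1cccc(-c2ccc3nccc(-c4ccncc4)c3n2)c1`, carries a ((oxetan-3-yl)methyl)amino group on its sulfonyl sulfur; in this assay compound 1 gives 19%. Compound 2, `O=S(=O)(NCc1ccccc1)c1cccc(Nc2ccc3nccc(-c4ccncc4)c3n2)c1`, reaches only 2% in this assay, and compound 3, `O=S(=O)(NCCN1CCCC1)c1cccc(-c2ccc3nccc(-c4ccnc(C(F)(F)F)c4)c3n2)c1`, gives 8%. Compound 1 therefore stands highest of the three numbers: its nearest neighbour is compound 3, whose value lies beyond the scatter below it, and compound 2 lies further still.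

Compound 4, `O=S(=O)(c1cccc(-c2ccc3nccc(-c4ccncc4)c3n2)c1)N1CC[C@H](O)C1`, has not yet been measured. It has the same atoms as compound 1, joined differently: 3-hydroxypyrrolidin-1-yl in place of ((oxetan-3-yl)methyl)amino on a sulfonyl sulfur. For the measured compounds named here, no pair among the measured compounds differs in only this one place, so there is no measured step to lean on.

With nothing to anchor the change, the expected step from compound 1 to compound 4 in this assay is a number 4 percentage points lower from compound 1 to compound 4 (within the scatter), which is within the scatter in either direction. On that basis compound 4 is expected to give about 15% in this assay, with a range from 4% to 35%.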

Compound 4, percent of the compound remaining: 12%
Beside the measured number, compound 4's estimate is 3 percentage points above it, and the stated range covers the measured number.
By their numbers in this assay, from the lowest: compounds 2, 3, 4 and 1 (each within the scatter of the next, the first and the last beyond it).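

For the compounds shown here, putting 3-hydroxypyrrolidin-1-yl in place of ((oxetan-3-yl)methyl)amino on a sulfonyl sulfur gives the first comparison here in which only one place differs, and in this assay it reads as a number 7 percentage points lower from compound 1 to compound 4 (within the scatter). The swap keeps the same atoms and the same counted hydrogen-bond donor and acceptor, but it replaces a four-membered non-aromatic ring with a five-membered one and adds a defined stereocentre, and on this evidence those changes together leave the two compounds indistinguishable in this read-out. Nothing measured alongside these numbers bears on why the step has this size.

Compounds 2 and 3 differ from compound 1 in more than one place, so the sulfonyl position has only this single step behind it, and a group of a different kind at that place, such as morpholine, piperazine or a longer chain ending in a carboxylic acid, remains untested among the compounds shown. Also open, from the compounds shown here alone, is how the mirror-image form of the 3-hydroxypyrrolidin-1-yl group would compare with compound 4 in this assay, since only one defined stereocentre arrangement appears here.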